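Notes on the step from compound 3 to compound 4

The source may hold more compounds than are shown below. What is called first, only, known or untested is meant among the compounds shown, and "the series" means these compounds.

So far, an ADME assay on microsomes from liver (Rattus norvegicus) for metabolic stability (a higher number here means that the compound lasts longer, a lower number that the compound disappears faster), gives limits for this series and no numbers. Compound 1 `N#Cc1ccc(-c2nc(NCCNc3ccc([N+](=O)[O-])c(N)n3)ncc2-c2ncc[nH]2)cc1` gives > 0.5 h, which is a limit. Compound 2 `Nc1nc(NCCNc2ncc(-c3ncc[nH]3)c(-c3ccc(C(F)(F)F)cc3)n2)ccc1[N+](=O)[O-]` gives > 0.5 h, again a limit. On these data alone, compound 3 `Nc1nc(NCCNc2ncc(-c3ncc[nH]3)c(-c3cc(F)ccc3Cl)n2)ccc1[N+](=O)[O-]` gives > 0.5 h, also a limit, so its true half-life remains unknown. All three compounds share one reading: the limit of > 0.5 h in this assay, at which 3 of the 3 values shown sit.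

Compound 4 `Nc1nc(NCCNc2ncc(-c3ncc[nH]3)c(-c3cc(F)c(Cl)cc3F)n2)ccc1[N+](=O)[O-]` carries 4-chloro-2,5-difluorophenyl in place of 2-chloro-5-fluorophenyl, on an aromatic carbon ortho to a 1H-imidazol-2-yl group: 4-chloro-2,5-difluorophenyl in place of 2-chloro-5-fluorophenyl on an aromatic carbon.

Going by the values given here, three measured steps bear on this change. Two replace the phenyl group at this same place, a step that the two limits leave unreadable from compound 1 to compound 3 and a step that the two limits leave unreadable from compound 2 to compound 3, and one changes a group on that phenyl, a step that the two limits leave unreadable from compound 1 to compound 2. None of them has a readable size, so no size can be carried over to the new step. All that can be said is that the three different phenyl groups give the same limit.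

The expectation therefore rests on compound 3, whose > 0.5 h is a limit. The expected step is a step that the limit leaves unreadable from compound 3 to compound 4, with no change beyond the scatter anticipated in this assay. For compound 4 the estimated half-life is 0.8 h, with an expected range of 0.4 h to 2 h.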

Compound 4, half-life: > 0.5 h
Compound 4 gave a limit, no number; the forecaster's own chance of this, stated with the estimate: 80%; the middle value lies beyond the limit too.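

The steps to compound 4 from compound 1, compound 2 and compound 3 cannot be read in this assay, and compound 4 ends where the others do: the limit of > 0.5 h in this assay, at which 4 of the 4 values shown sit.

The compounds shown leave open the true half-life of each of compound 1, compound 2, compound 3 and compound 4, and so whether the substituted phenyl groups differ at all.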